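A few compounds are considered here, and "the series" means these few. Any claim that something is new, unique, unknown or untested is made for them only; others in the source may bear on it.

Compound 1 `Cc1ccc(C(=O)OC2(C(=O)Nc3ccc([N+](=O)[O-])cc3)CCCCC2)cc1`: in a functional assay on NFS-60 cells (Mus musculus) for inhibition, read by MTT assay, with a stated time of 72 h (on this read-out lower numbers stand for stronger inhibition and higher numbers for weaker inhibition), compound 1 gives 45.4 nM.
Compound 2 `CCOC(=O)c1ccccc1C(=O)OC1(C(=O)Nc2ccc([N+](=O)[O-])cc2)CCCCC1`: in this assay compound 2 gives 488 nM.
Compound 3 `O=C(/C=C/c1ccccc1)OC1(C(=O)Nc2ccc([N+](=O)[O-])cc2)CCCCC1`: in this assay compound 3 gives 50.5 nM.

All three compounds share one core and differ only in the group attached to the ester carbonyl carbon. Compound 3 stands second highest of the three numbers; its nearest neighbour is compound 1, and the two lie within the scatter of each other, so no order between them can be claimed. Compound 2 stands far from both, with its value clearly higher than that of compound 3.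

Compound 4 `O=C(OC1(C(=O)Nc2ccc([N+](=O)[O-])cc2)CCCCC1)c1ccccc1` has not yet been measured. It differs from compound 3 by phenyl in place of 2-phenylethenyl on a carbonyl carbon. Going by the values given here, only one measured step bears on this place: a 1.1-fold higher number from compound 1 to compound 3 (0.05 log units; within the scatter), which swapped one carbon-based group for another at the same position and left the number essentially unchanged. Compound 2 shows that a larger, more elaborate group at this position can push the number up sharply, but compound 4 carries the smallest group of the set.

Compound 4 is therefore expected to show essentially no change beyond the scatter, a 1.1-fold higher number from compound 3 to compound 4 (0.04 log units; within the scatter), giving an estimated 55 nM with a range from 25 nM to 130 nM.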

Compound 4, half-maximal inhibitory concentration: 766 nM
Compound 4: middle estimate off by 14-fold (1.14 log units), on the low side, and the stated range ends below it.
By their numbers in this assay, from the lowest: compounds 1 and 3 (each within the scatter of the next); then compounds 2 and 4 (each within the scatter of the next).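

In this assay, phenyl in place of 2-phenylethenyl on the carbonyl carbon gives a 15-fold higher number from compound 3 to compound 4 (1.18 log units; beyond the scatter), so this position is far less tolerant of change than the close match between compound 1 and compound 3 had suggested. A single methyl on the aromatic ring carries a step of the same scale, since hydrogen in its place gives a 17-fold higher number from compound 1 to compound 4 (1.23 log units; beyond the scatter), whereas hydrogen in place of ethoxycarbonyl gives a 1.6-fold higher number from compound 2 to compound 4 (0.20 log units; within the scatter), which leaves compound 2 and compound 4 within the scatter of each other. Among these four compounds, the number of atoms in the group therefore does not set the order: phenyl, the smallest group, falls with the larger ethoxycarbonyl-bearing group of compound 2, while the 4-methylphenyl of compound 1 and the 2-phenylethenyl of compound 3 give the low numbers.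

No measurement here explains why these groups separate in this way. From the compounds shown here alone, it remains open whether a methoxy group or an amine in place of the methyl of compound 1 would keep the low number, and whether 2-phenylethyl in place of 2-phenylethenyl would do so for compound 3.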